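The source may report more compounds than this note shows. Statements on the series, on what has been measured and on what is new or still open speak of the compounds shown alone.

In a functional assay on A549 cells (Homo sapiens) for antiproliferative activity, read by MTT assay, with a stated time of 48 h (on this read-out higher numbers stand for weaker inhibition and lower numbers for stronger inhibition), compound 1 (`CN(C)CCn1c(N)c(-c2nc3ccccc3[nH]2)c2nc(C#N)c(C#N)nc21`) gives > 50000 nM as a limit and not a number. Compound 2 (`CCN(CC)CCn1c(N)c(-c2nc3ccccc3[nH]2)c2nc(C#N)c(C#N)nc21`) gives > 50000 nM as a limit as well. Compound 3 (`CN(C)CCn1c(N)c(-c2nc3ccccc3n2C)c2nc(C#N)c(C#N)nc21`) also gives > 50000 nM as a limit, so it has no number of its own. The whole set shows only the limit of > 50000 nM in this assay, at which 3 of the 3 values shown sit, and nothing more. Compound 4 (`CCN(CC)CCn1c(N)c(-c2nc3ccccc3n2C)c2nc(C#N)c(C#N)nc21`) departs from compound 3 by one change, (diethylamino in place of dimethylamino on a saturated chain carbon, two bonds along the chain from an aromatic nitrogen), which places diethylamino in place of dimethylamino on a saturated chain carbon, two bonds along the chain from an aromatic nitrogen. The same swap on the other parent is a step that the two limits leave unreadable from compound 1 to compound 2 and the methyl on the aromatic nitrogen is a step that the two limits leave unreadable from compound 1 to compound 3, so neither gives a size to carry over. With no readable step behind it, no change beyond the scatter is expected. The expected step is a number no higher from compound 3 to compound 4 (the limit leaves the size open) and rests on compound 2 staying at > 50000 nM after the same swap. For compound 4 the estimated value is 50000 nM, with an expected range from 20000 nM to 100000 nM, and most likely the assay will report only a limit again.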

Compound 4, half-maximal inhibitory concentration: > 50000 nM
Compound 4: only a limit was reported; the forecaster's own chance of this, stated with the estimate: 80%; the middle value sits exactly at the limit.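

No step can be read for compound 4 against compound 3 or compound 2 in this assay, as the result is again only a limit: the limit of > 50000 nM in this assay, at which 4 of the 4 values shown sit.

The compounds shown leave open whether either diethylamino in place of dimethylamino or methyl in place of hydrogen on an aromatic nitrogen changes activity at all.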